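The source may report more compounds than this note shows. Statements on the series, on what has been measured and on what is new or still open speak of the compounds shown alone.

The measured compounds and their results in an assay on HL-60 cells for agonist activity at vitamin D3 receptor (Homo sapiens), read by microscopy, with a stated time of 96 h; on this read-out lower numbers stand for an effect already at smaller amounts and higher numbers for an effect only at larger amounts of compound:

compound 1, `CCN(CC)CCCNC(=O)c1ccc(C(CC)(CC)c2ccc(OCC(=O)C(C)(C)C)c(C)c2)n1CC`: 22 nM
compound 2, `CCN(CC)CCCNC(=O)c1ccc(C(CC)(CC)c2ccc(OCC(O)C(C)(C)C)c(C)c2)n1CC`: 66 nM
compound 3, `CCn1c(C(=O)Nc2ccc(OC(F)(F)F)cc2)ccc1C(CC)(CC)c1ccc(OCC(=O)C(C)(C)C)c(C)c1`: a limit of the assay, > 50000 nM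

Compound 2 stands at the higher of the two numbers that were obtained. Within the data shown here, the only other number, that of compound 1, lies lower: a 3.0-fold higher number from compound 1 to compound 2 (0.48 log units; beyond the scatter). The third result, that of compound 3, is a limit and not a number.

Compound 4, `CCn1c(C(=O)OCc2ccc(F)cc2)ccc1C(CC)(CC)c1ccc(OCC(O)C(C)(C)C)c(C)c1`, differs from compound 2 at the carbonyl carbon: (4-fluorobenzyl)oxy in place of (3-(diethylamino)propyl)amino on a carbonyl carbon. Among the measured compounds shown here, one measured step bears on this change. When the 3-(diethylamino)propyl group on the amide-type nitrogen of compound 1 was exchanged for a 4-(trifluoromethoxy)phenyl group, the result moved far: an at least 2200-fold higher number from compound 1 to compound 3 (3.35 log units; beyond the scatter), reaching (the limit of > 50000 nM in this assay, at which 1 of the 3 values shown sits). In compound 4 the (3-(diethylamino)propyl)amino group leaves as well, and the amide-type nitrogen leaves with it, so a large step upward in this assay is expected, most probably again ending at the limit rather than at a number. Compound 4 is therefore estimated at about 60000 nM, with a range from 5000 nM to 500000 nM. The expected step is a 910-fold higher number from compound 2 to compound 4 (2.96 log units; beyond the scatter).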

Compound 4, half-maximal effective concentration: > 50000 nM
Compound 4 gave a limit, no number (the forecaster's own chance of this, stated with the estimate: 70%); the middle value lies beyond the limit too.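

In this assay, from the compounds shown here alone, replacing (3-(diethylamino)propyl)amino with (4-fluorobenzyl)oxy on a carbonyl carbon gives an at least 750-fold higher number from compound 2 to compound 4 (2.87 log units; beyond the scatter); the true size of this step is unknown, since the result for compound 4 is a limit and not a number. The earlier large step had kept the amide-type nitrogen and was seen with the (tert-butyl)carbonyl side chain, whereas this one removes that nitrogen and was seen with the 1-hydroxy-2,2-dimethylpropyl side chain, so the collapse at this position is no longer tied to a single side chain. Among the compounds shown, the two that keep the 3-(diethylamino)propyl group give numbers, while compound 3 and compound 4, which both lack it, end at the limit: the limit of > 50000 nM in this assay, at which 2 of the 4 values shown sit.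

The compounds shown do not separate the loss of the diethylamino group from the loss of the amide link, as a 3-(diethylamino)propyl ester or a 4-fluorobenzyl amide on the same carbonyl carbon would. Going by these compounds, how far the amine can be varied also stays open, for instance with a 3-(dimethylamino)propyl chain, a longer chain or a piperidine in its place.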